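The source may report more compounds than this note shows. Statements on the series, on what has been measured and on what is new or still open speak of the compounds shown alone.

In a functional assay on MCF7 cells (Homo sapiens) for inhibition, read by MTT assay (a higher number here means a weaker inhibitor, a lower number a stronger inhibitor), compound 1 (`COc1cc2ncnc(Nc3ccc(NC(=O)c4ccccc4F)cc3)c2cc1OC`) gives 11000 nM, and compound 2 (`COc1cc2ncnc(Nc3ccc(NC(=O)c4ccccc4Cl)cc3)c2cc1OC`) gives 36000 nM, the higher of the two numbers, which makes compound 2 the weaker inhibitor of this pair. Compound 3 (`COc1cc2ncnc(Nc3ccc(NC(=O)c4ccc(I)cc4)cc3)c2cc1OC`) has not yet been measured. Its difference from compound 2 is 4-iodophenyl in place of 2-chlorophenyl on a carbonyl carbon. In short, it has 4-iodophenyl in place of 2-chlorophenyl on a carbonyl carbon. For the measured compounds named here, the only measured step that bears on this is a 3.3-fold higher number from compound 1 to compound 2 (0.51 log units; beyond the scatter), a modest change with chloro in place of fluoro on an aromatic carbon. Going by the values given here, no measured compound carries a 4-iodophenyl group, so that step is only a rough guide to size and gives no firm direction. The estimate means a 1.8-fold lower number from compound 2 to compound 3 (0.26 log units; within the scatter), so no clear step beyond the scatter is expected. For compound 3 the expected value is 20000 nM, with an estimated range from 6000 nM to 60000 nM.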

Compound 3, half-maximal inhibitory concentration: 48000 nM
For compound 3 the middle estimate is 2.4-fold (0.38 log units) below the measured one; the measured number falls inside the stated range.
By their numbers in this assay, from the lowest: compound 1; then compounds 2 and 3 (each within the scatter of the next).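

In this assay, putting 4-iodophenyl in place of 2-chlorophenyl on the carbonyl carbon gives a 1.3-fold higher number from compound 2 to compound 3 (0.12 log units; within the scatter) and so cannot be told apart from no change, even though the halogen and its numbered ring position both differ. Putting the same 4-iodophenyl in place of 2-fluorophenyl gives a 4.4-fold higher number from compound 1 to compound 3 (0.64 log units; beyond the scatter) and this lies beyond the scatter, so among these three amides only the 2-fluorophenyl one stands apart from the other two. Nothing measured here offers a reason for these numbers.

The compounds shown do not separate the effect of the halogen from that of its ring position, as a 4-fluorophenyl or a 2-iodophenyl group would. They also leave open how a non-halogen group on that phenyl ring, such as a methoxy, an amine or a carboxylic acid, would compare.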